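Aryl exchange on the amide of compound 2

A few compounds are considered here, and "the series" means these few. Any claim that something is new, unique, unknown or untested is made for them only; others in the source may bear on it.

Of the compounds shown here, two so far carry numbers in a functional assay on SEM cells (Homo sapiens) for inhibition, read by MTT assay, with a stated time of 72 h; on this read-out lower numbers stand for stronger inhibition and higher numbers for weaker inhibition. Compound 1 (`COc1cccc(/C=C/C(=O)Nc2cc(OC)c(OC)c(OC)c2)c1`) gives 18200 nM. Compound 2 (`C=C(Br)C(=O)Nc1cccc(/C=C/C(=O)Nc2cccc(F)c2)c1`) gives 620 nM, the lower of the two numbers, and its gap to compound 1 lies beyond the scatter. The two structures differ in more than one place, so that gap cannot be assigned to any single group.

The next compound to be read is compound 3 (`C=C(Br)C(=O)Nc1cccc(/C=C/C(=O)Nc2ccc(C)cc2)c1`), which has 4-methylphenyl in place of 3-fluorophenyl on an amide-type nitrogen. The rest of the structure of compound 2 is kept. Among the measured compounds shown here, no measured pair tests a change at this place, so the expectation is weakly founded and leans on compound 2 at 620 nM as the only close reference. The expected size of a 1.1-fold lower number from compound 2 to compound 3 (0.03 log units; within the scatter) in this assay stays within the scatter, with no direction favoured. For compound 3 the estimated value is 580 nM, with an expected range from 200 nM to 1700 nM.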

Compound 3, half-maximal inhibitory concentration: 190 nM
Estimate against measurement, compound 3: 3.1-fold (0.48 log units) above, outside the stated range (below it).
By their numbers in this assay, from the lowest: compound 3; then compound 2; then compound 1.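

In this assay, among the compounds shown here, 4-methylphenyl in place of 3-fluorophenyl on an amide-type nitrogen gives a 3.3-fold lower number from compound 2 to compound 3 (0.51 log units; beyond the scatter) and is the first single change that can be read. This position therefore responds to an aryl exchange, although the two groups have the same count of heavy atoms, the same count of hydrogen-bond donors and acceptors, and no net charge, and each is one six-membered aromatic ring of carbon only. No measurement at hand accounts for the shift in the number.

This single step changes both the substituent and its place on the phenyl ring, so it cannot say which of the two matters, and 4-fluorophenyl and 3-methylphenyl would be the groups to tell them apart. Also open, going by these compounds, is how the number in this assay behaves with an amine or a carboxylic acid on that ring, and whether a ring other than phenyl on the same nitrogen keeps it in the range of compound 3.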